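The compounds below may be only part of what the source reports. "The series", "measured", "known", "first", "only" and "open" are said of these compounds alone.

Values in an assay on membranes from CHO cells for displacement of a labelled ligand from adenosine receptor A1 (Homo sapiens), read by scintillation counting, with a stated time of 60 min, tested at 1 uM; a higher number here means more inhibition at the concentration tested (going by the name of the read-out), a lower number less inhibition:
compound 1 `CCNC(=O)C1=C(C)NC(=O)NC1c1ccsc1`: 3%
compound 2 `CCN(CC)C(=O)C1=C(C)NC(=O)NC1c1ccsc1`: 11%

For the measured compounds named here, compound 2 holds the higher of the two numbers, but its only neighbour is compound 1, and the step of a number 8 percentage points higher from compound 1 to compound 2 (within the scatter) lies within the scatter, so the two compounds cannot be told apart on these readings. Both sit at the low end of the inhibition scale.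

Compound 3 `CCSC(=O)C1=C(C)NC(=O)NC1c1ccsc1` has not been measured. It differs from compound 2 by ethylsulfanyl in place of diethylamino on a carbonyl carbon. Going by the values given here, the one measured step, a number 8 percentage points higher from compound 1 to compound 2 (within the scatter), concerns the substituent on the amide-type nitrogen rather than the group attached to the carbonyl carbon, and it was within the scatter; it therefore gives no direct precedent for this change, only the observation that variation at the amide end of the core has left the low reading unmoved.

The expectation for compound 3 is accordingly a step of a number 3 percentage points lower from compound 2 to compound 3 (within the scatter), no change beyond the scatter. Compound 3 is estimated at 8%, with a range of 0% to 20%.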

Compound 3, a percentage reported as inhibition, at one concentration (the size of the read-out at that concentration, not a potency): 11%
The estimate for compound 3 lay 3 percentage points below the measured number; the range from low to high includes it.
By their numbers in this assay, from the lowest: compounds 1, 2 and 3 (each within the scatter of the next).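

In this assay, the carbonyl carbon now carries a group without nitrogen: ethylsulfanyl in place of diethylamino gives no change at the digits printed from compound 2 to compound 3 (within the scatter), and ethylsulfanyl in place of ethylamino gives a number 8 percentage points higher from compound 1 to compound 3 (within the scatter). The earlier pair varied only the substituent on the amide-type nitrogen, whereas these steps replace that nitrogen with sulfur, and neither step separates the compounds on these readings, so the presence of the amide-type nitrogen at this position makes no difference that can be read among compound 1, compound 2 and compound 3. No measurement is at hand that would explain these readings.

Going by these compounds, what an ethoxy group, a hydroxyl group as in the carboxylic acid, or a longer chain on the sulfur would give on the same carbonyl carbon remains open. Also open is whether any group at this position can move the reading in this assay beyond the scatter, since the three compounds shown cannot be told apart.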